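Aryl group variation on a shared core: estimate for compound 4

The source may hold more compounds than are shown below. What is called first, only, known or untested is meant among the compounds shown, and "the series" means these compounds.

In an assay on isolated protein for inhibition of Dihydrofolate reductase (Homo sapiens), read by spectrophotometry, using NADPH, with stated times of 5 s and 6 min, tested at 5 uM (on this read-out lower numbers stand for a weaker effect and higher numbers for a stronger effect at the one concentration tested), the three measured compounds give:
compound 1 `NC1=NC2(CCSCC2)N(OCCCOc2cccc(Cl)c2Cl)C(N)=N1`: 83.8%
compound 2 `COc1ccc(OCCCON2C(N)=NC(N)=NC23CCSCC3)cc1`: 81.3%
compound 3 `NC1=NC2(CCSCC2)N(OCCCOc2cc(Cl)c(Cl)cc2Cl)C(N)=N1`: 84.4%

Compound 3 gives the largest of the three numbers, but neither a number 0.6 percentage points higher from compound 1 to compound 3 (within the scatter) nor a number 3.1 percentage points higher from compound 2 to compound 3 (within the scatter) lies beyond the scatter, so no ranking among compounds 1, 2 and 3 follows from these values.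

The unmeasured compound 4 `NC1=NC2(CCSCC2)N(OCCCOc2cccc(Br)c2)C(N)=N1` differs from compound 3 at one place: 3-bromophenyl in place of 2,4,5-trichlorophenyl on an oxygen on a saturated carbon.

All three measured steps concern the same position, the aryl group on the oxygen on a saturated carbon. a number 2.5 percentage points lower from compound 1 to compound 2 (within the scatter), a number 0.6 percentage points higher from compound 1 to compound 3 (within the scatter) and a number 3.1 percentage points higher from compound 2 to compound 3 (within the scatter) are each within the scatter, although they exchange a 2,3-dichlorophenyl, a 4-methoxyphenyl and a 2,4,5-trichlorophenyl, groups that differ in kind and in count of heavy atoms. Going by the values given here, no measured step at this position moves the number beyond the scatter, and no other position has been varied. The exchange for a 3-bromophenyl is therefore expected to give no step beyond the scatter in this assay, that is, a step of about a number 1.4 percentage points lower from compound 3 to compound 4 (within the scatter).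

Among the compounds with values here, for compound 4 the expected value in this assay is 83%, with a range from 72% to 91%, set wide because only three compounds support the estimate.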

Compound 4, a percentage reported as inhibition, at one concentration (the size of the read-out at that concentration, not a potency): 84.2%
Compound 4: the middle estimate sits 1.2 percentage points below what was measured; measured number inside the range.
By their numbers in this assay, from the lowest: compounds 2, 1, 4 and 3 (each within the scatter of the next).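

In this assay, the 3-bromophenyl group gives a number 0.2 percentage points lower from compound 3 to compound 4 (within the scatter), a number 2.9 percentage points higher from compound 2 to compound 4 (within the scatter) and a number 0.4 percentage points higher from compound 1 to compound 4 (within the scatter), so all four aryl groups shown on this oxygen on a saturated carbon now stand within the scatter of one another. Going by these compounds alone, this adds two things to the earlier compounds: bromine now appears on the aryl ring, and the exchange from 2,4,5-trichlorophenyl with 9 heavy atoms to 3-bromophenyl with 7 heavy atoms produces no step beyond the scatter. No measurement at hand bears on why these aryl groups read alike in this assay.

Going by these compounds, all four compounds carry an aryl group at this place on the same shared core, so the reading for an amine or a carboxylic acid in place of that group, or for a longer chain carrying it, remains open. On these data alone, the read-out is also taken at a single concentration and gives the size of the effect there, so whether compounds 1, 2, 3 and 4 differ in potency also remains open.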